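Replacing cyclopropyl in a series with level cytotoxicity

A few compounds are considered here, and "the series" means these few. Any claim that something is new, unique, unknown or untested is made for them only; others in the source may bear on it.

- Compound 1 `CNC(=O)CCCCn1c(=O)c(C)cn([C@@H]2O[C@H](CO[Si](C)(C)C(C)(C)C)[C@@]3(OS(=O)(=O)C=C3N)[C@H]2O[Si](C)(C)C(C)(C)C)c1=O` gives 10000 nM
- Compound 2 `Cc1cn([C@@H]2O[C@H](CO[Si](C)(C)C(C)(C)C)[C@@]3(OS(=O)(=O)C=C3N)[C@H]2O[Si](C)(C)C(C)(C)C)c(=O)n(C(=O)CCCBr)c1=O` gives 11000 nM
- Compound 3 `Cc1cn([C@@H]2O[C@H](CO[Si](C)(C)C(C)(C)C)[C@@]3(OS(=O)(=O)C=C3N)[C@H]2O[Si](C)(C)C(C)(C)C)c(=O)n(C(=O)C2CC2)c1=O` gives 11000 nM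

In an ADME assay on CCRF-CEM cells (Homo sapiens) for cytotoxicity, with a stated time of 4 days (a lower number here means that less compound is tolerated, a higher number that more compound is tolerated), compound 3 gives 11000 nM, level with compound 2 and within the scatter of compound 1. Compound 4 `CNC(=O)CCCC(=O)n1c(=O)c(C)cn([C@@H]2O[C@H](CO[Si](C)(C)C(C)(C)C)[C@@]3(OS(=O)(=O)C=C3N)[C@H]2O[Si](C)(C)C(C)(C)C)c1=O` carries 3-(methylcarbamoyl)propyl in place of cyclopropyl on a carbonyl carbon. Within the data shown here, two measured steps bear on this change. Exchanging the group on that carbonyl carbon gave no change at the digits printed from compound 2 to compound 3 (within the scatter). Replacing 4-(methylcarbamoyl)butyl with cyclopropylcarbonyl gave a 1.1-fold higher number from compound 1 to compound 3 (0.04 log units; within the scatter). Neither step leaves the scatter, so no step beyond it is expected in this assay. The expected step is no change at the digits printed from compound 3 to compound 4 (within the scatter). Compound 4 is estimated at 11000 nM, with an expected range from 6000 nM to 20000 nM.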

Compound 4, half-maximal cytotoxic concentration: 9100 nM
Compound 4: the middle estimate sits 1.2-fold (0.08 log units) above what was measured; measured number inside the range.
By their numbers in this assay, from the lowest: compounds 4, 1, 2 and 3 (each within the scatter of the next).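

In this assay, replacing the cyclopropyl ring on the carbonyl carbon with the open 3-(methylcarbamoyl)propyl chain, which adds a hydrogen-bond donor and acceptor, gave a 1.2-fold lower number from compound 3 to compound 4 (0.08 log units; within the scatter). Methylcarbamoyl in place of bromo gave a 1.2-fold lower number from compound 2 to compound 4 (0.08 log units; within the scatter), and (3-(methylcarbamoyl)propyl)carbonyl in place of 4-(methylcarbamoyl)butyl on the aromatic nitrogen gave a 1.1-fold lower number from compound 1 to compound 4 (0.04 log units; within the scatter). No available measurement explains why these numbers stay level. On these data alone, whether an amine or a carboxylic acid on this chain would also stay level remains open, as does whether a compound without the group would differ.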